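Working notes: from compound 1 to compound 4

The source may report more compounds than this note shows. Statements on the series, on what has been measured and on what is new or still open speak of the compounds shown alone.

Measured in an ADME assay on HEL cells (Homo sapiens) for cytotoxicity; on this read-out lower numbers stand for higher toxicity in this test and higher numbers for lower toxicity in this test:
- compound 1 `O=C(COc1cccc2ccccc12)N/N=C/c1ccccc1Br`: 100 ug/mL
- compound 2 `C/C(=N\NC(=O)COc1cccc2ccccc12)c1ccc(Cl)cc1`: 7.1 ug/mL
- compound 3 `C/C(=N\NC(=O)COc1cccc2ccccc12)c1ccccc1O`: 4 ug/mL

Compound 1 stands highest of the three, and its distance to each of the other two lies beyond the scatter. Both of those compounds differ from compound 1 in more than one place, so that distance cannot be assigned to any single change.

Compound 4 `O=C(COc1cccc2ccccc12)N/N=C/c1ccccc1` carries hydrogen in place of bromo on an aromatic carbon, ortho to a large group (hydrogen in place of bromo on an aromatic carbon). Among the compounds with values here, no measured step removes a bromo group. Within the data shown here, the only measured step, a 1.8-fold lower number from compound 2 to compound 3 (0.25 log units; within the scatter), exchanges 4-chlorophenyl for 2-hydroxyphenyl, so it bears on this change only indirectly. It lies within the scatter and offers weak support for a small step. Compound 1 holds the highest number, so any departure is expected to lean towards a lower number in this assay, with no firm shift beyond the scatter. The expected change is a 1.7-fold lower number from compound 1 to compound 4 (0.22 log units; within the scatter). For compound 4 the estimated value is 60 ug/mL, with an expected range from 15 ug/mL to 150 ug/mL.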

Compound 4, half-maximal cytotoxic concentration: 64.5 ug/mL
Beside the measured number, compound 4's estimate is 1.1-fold (0.03 log units) below it; low and high end bracket the measured number.
By their numbers in this assay, from the lowest: compounds 3 and 2 (each within the scatter of the next); then compounds 4 and 1 (each within the scatter of the next).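

Within the data shown here, removing the bromo group from this aromatic carbon, ortho to a large group, gives the only single-place step at this position, and in this assay it reads as a 1.6-fold lower number from compound 1 to compound 4 (0.19 log units; within the scatter). The change from 2-bromophenyl to phenyl therefore cannot be told from the scatter on this read-out, so this bromo group can give way to hydrogen with no measurable shift. No measured data offer an explanation for the size of this step.

From the compounds shown here alone, whether an amine, a methoxy group or a carboxylic acid at this place would also leave the number within the scatter remains open. Also open, going by these compounds, is whether hydrogen in place of bromo would give a step of similar size on the core of compound 2 or compound 3.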